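Replacing the 2-fluoro-5-nitrophenyl group of compound 3

A few compounds are considered here, and "the series" means these few. Any claim that something is new, unique, unknown or untested is made for them only; others in the source may bear on it.

In a functional assay on DU-145 cells (Homo sapiens) for inhibition, read by trypan blue exclusion, with a stated time of 96 h (a lower number here means a stronger inhibitor of growth, a higher number a weaker inhibitor of growth), compound 1 (`CSc1ccc(/C=C(\C(=O)c2ccc(Br)cc2)S(=O)(=O)Cc2ccc(F)cc2)cc1`) gives 50000 nM and compound 2 (`Cc1ccc(/C=C(\C(=O)c2ccc(Br)cc2)S(=O)(=O)Cc2ccc(F)cc2)s1`) gives 1000 nM. Compound 3 (`O=C(/C(=C\c1cc([N+](=O)[O-])ccc1F)S(=O)(=O)Cc1ccc(F)cc1)c1ccc(Br)cc1`) stands at > 100000 nM, which is a limit of the assay and not a number. Compound 4 (`O=C(/C(=C\c1ccc(O)cc1)S(=O)(=O)Cc1ccc(F)cc1)c1ccc(Br)cc1`) carries 4-hydroxyphenyl in place of 2-fluoro-5-nitrophenyl on a double-bonded chain carbon bound to a double-bonded chain carbon. Three measured steps at this same place bear on the change: a 50-fold lower number from compound 1 to compound 2 (1.70 log units; beyond the scatter), an at least 2.0-fold higher number from compound 1 to compound 3 (0.30 log units; that floor lies within the scatter) and an at least 100-fold higher number from compound 2 to compound 3 (2.00 log units; beyond the scatter). The group exchanged here can therefore move the result in this assay by a large amount, although the 4-hydroxyphenyl group itself has not been measured. The closest comparison is compound 1, whose 4-(methylsulfanyl)phenyl group gives 50000 nM, so a measurable number is expected for compound 4. The expected change is an at least 5.0-fold lower number from compound 3 to compound 4 (0.69 log units; beyond the scatter), towards stronger growth inhibition. For compound 4 the estimated value is 20000 nM, with an expected range of 3000 nM to 100000 nM.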

Compound 4, concentration for 50% growth inhibition: 10000 nM
Estimate against measurement, compound 4: 2.0-fold (0.30 log units) above; low and high end bracket the measured number.
By their numbers in this assay, from the lowest: compound 2; then compound 4; then compound 1. At a limit, above all of these: compound 3.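

At this place, on a double-bonded chain carbon bound to a double-bonded chain carbon, 4-hydroxyphenyl gives a measurable result in this assay, with an at least 10-fold lower number from compound 3 to compound 4 (1.00 log units; beyond the scatter). Compound 3 stands at a limit of the assay and not a number, so this step gives only a floor: the limit of > 100000 nM in this assay, at which 1 of the 4 values shown sits. A change on the phenyl ring alone also moves the result, as hydroxy in place of methylsulfanyl on an aromatic carbon gives a 5.0-fold lower number from compound 1 to compound 4 (0.70 log units; beyond the scatter), yet neither phenyl compound reaches the thiophene compound, with a 10-fold higher number from compound 2 to compound 4 (1.00 log units; beyond the scatter).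

The compounds shown leave open whether an amine or a methoxy group in place of the hydroxy would keep or extend this gain. They also leave open whether the methyl on the 5-methylthiophen-2-yl group contributes to its lower number, which a plain thiophen-2-yl group would test.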